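Swapping a Thiazole for a Methylpiperazine on the Core

A few compounds are considered here, and "the series" means these few. Any claim that something is new, unique, unknown or untested is made for them only; others in the source may bear on it.

Among the measured compounds shown here, compound 3 `CC/C(=C(/c1ccc(/C=C/C(=O)O)cc1)c1ccc(-c2cscn2)cc1)c1ccccc1` holds the only numeric value in this set: in a functional assay on MCF7 cells (Homo sapiens) for antiproliferative activity, read by CellTiter-Glo, with a stated time of 5 days (a lower number here means a stronger inhibitor, a higher number a weaker inhibitor), compound 3 gives 120 nM. Compound 1 `CC/C(=C(/c1ccc(/C=C/C(=O)O)cc1)c1ccc2nncn2c1)c1ccccc1` reaches only a limit of the assay, > 500 nM. Compound 2 `CC/C(=C(/c1ccc(/C=C/C(=O)O)cc1)c1ccc2sncc2c1)c1ccccc1` likewise stops at a limit, > 500 nM. For the measured compounds named here, the one measured step, a step that the two limits leave unreadable from compound 1 to compound 2, therefore cannot be sized, as the limit of > 500 nM in this assay, at which 2 of the 3 values shown sit, shows. Compound 4 `CC/C(=C(/c1ccc(/C=C/C(=O)O)cc1)c1ccc(N2CCN(C)CC2)cc1)c1ccccc1` differs from compound 3 by 4-methylpiperazin-1-yl in place of 1,3-thiazol-4-yl on an aromatic carbon. Going by the values given here, no measured step covers this kind of exchange, so its direction cannot be read from these data, and a moderate step either way remains possible. Compound 4 is therefore expected to give 250 nM, with a range from 60 nM to 900 nM. The expected step is a 2.1-fold higher number from compound 3 to compound 4 (0.32 log units; beyond the scatter), carrying the wide uncertainty of an untested exchange.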

Compound 4, half-maximal inhibitory concentration: 220 nM
Compound 4: the middle estimate sits 1.1-fold (0.06 log units) above what was measured; measured number inside the range.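

In this assay the exchange on this aromatic carbon gives a 1.8-fold higher number from compound 3 to compound 4 (0.26 log units; within the scatter) and so does not separate the two groups. Among the compounds shown here, the position thus accepts either a five-membered aromatic ring or a six-membered non-aromatic ring with no change beyond the scatter, something the earlier compounds, with only one number among them, could not show.

Going by these compounds, whether a morpholine or a simple open-chain amine on this carbon would hold the same level stays open. The step between compound 1 and compound 2 also remains unreadable, and both values are limits: the limit of > 500 nM in this assay, at which 2 of the 4 values shown sit.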